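Removing the nitro group: expected cytotoxicity of compound 4

A few compounds are considered here, and "the series" means these few. Any claim that something is new, unique, unknown or untested is made for them only; others in the source may bear on it.

Compound 2 `C#CCN(c1nc(-c2cccc([N+](=O)[O-])c2)no1)C1CCCCC1` was tested in an ADME assay on HepG2 cells (Homo sapiens) for cytotoxicity, read by MTT assay, with a stated time of 48 h (a lower number here means that less compound is tolerated, a higher number that more compound is tolerated), where compound 2 gives 45.5 ug/mL. Among the three measured compounds this is the highest number, but the distances to the other two are within the scatter, so no order can be read from it. Compound 1 `CC(=O)OC[C@H]1O[C@H](OC[C@@H](Cn2cc(CN(c3nc(-c4cccc(C)c4)no3)C3CCCCC3)nn2)OC(C)=O)C=C[C@@H]1OC(C)=O` gives 39.2 ug/mL in this assay, and compound 3 `CC(=O)OC[C@H]1O[C@H](OC[C@@H](Cn2cc(CN(c3nc(-c4ccc(C)cc4)no3)C3CCCCC3)nn2)OC(C)=O)C=C[C@@H]1OC(C)=O` gives 36.8 ug/mL. Among the compounds with values here, the only step between measured compounds that differ in a single place, a 1.1-fold lower number from compound 1 to compound 3 (0.03 log units; within the scatter), stays within the scatter.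

Compound 4 `C#CCN(c1nc(-c2ccccc2)no1)C1CCCCC1` differs from compound 2 in one place: hydrogen in place of nitro on an aromatic carbon. Within the data shown here, no measured pair shows what removing a nitro group does in this assay; the one measured step concerns a methyl group alone and was within the scatter. With nothing in the data pointing to a change in either direction, the expectation for compound 4 is a number close to that of compound 2, with a step of a 1.1-fold lower number from compound 2 to compound 4 (0.03 log units; within the scatter) that is estimated to stay within the scatter. Compound 4 is therefore expected to give about 42 ug/mL in this assay, within a range from 22 ug/mL to 80 ug/mL.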

Compound 4, half-maximal cytotoxic concentration: 109 ug/mL
Beside the measured number, compound 4's estimate is 2.6-fold (0.41 log units) below it; the whole stated range lies below it.
By their numbers in this assay, from the lowest: compounds 3, 1 and 2 (each within the scatter of the next); then compound 4.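

In this assay, a 2.4-fold higher number from compound 2 to compound 4 (0.38 log units; beyond the scatter), so on this aromatic carbon, meta to a large group, hydrogen in place of nitro goes with more compound being tolerated by the cells. This is the only step among the compounds shown that lies beyond the usual scatter; the earlier step, a 1.1-fold lower number from compound 1 to compound 3 (0.03 log units; within the scatter), concerned the placing of a methyl group and stayed within it, so it gave no sign that a change on this six-membered aromatic ring could shift the number at all. No measurement at hand accounts for the size or direction of the new step, so the data record the change without explaining it.

Still open, on these data alone, is whether the higher number belongs to the loss of nitro in particular or would also appear with another group at the same place, such as an amine or a methoxy group on the core of compound 4. As far as these compounds go, this is also a single pair on a single core, so whether the same exchange would give a similar step on any other core remains unknown.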